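Swapping a pentylphenyl arm for a silyl group on a triazole

The source may report more compounds than this note shows. Statements on the series, on what has been measured and on what is new or still open speak of the compounds shown alone.

The measured compounds are:
compound 1, `CCCCCc1ccc(-c2cn(C[C@H](O)[C@H]3OC(=O)C(OCc4ccccc4)=C3OCc3ccccc3)nn2)cc1`, 8390 nM;
compound 2, `COc1ccccc1-c1cn(C/C=C2\OC(=O)C(OCc3ccccc3)=C2OCc2ccccc2)nn1`, > 100000 nM.

Within the data shown here, in a functional assay on HeLa cells (Homo sapiens) for antiproliferative activity, read by MTT assay, with a stated time of 72 h (on this read-out higher numbers stand for weaker inhibition and lower numbers for stronger inhibition), compound 1 gives 8390 nM, the only numerical value in the set. For compound 2 the assay reports a limit, > 100000 nM, and no number; this is the situation described by the limit of > 100000 nM in this assay, at which 1 of the 2 values shown sits. Among the measured compounds shown here, compound 1 and compound 2 differ at more than one place, so their two values say only that compound 2 was not resolved where compound 1 was.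

Compound 3, `C[Si](C)(C)c1cn(C[C@H](O)[C@H]2OC(=O)C(OCc3ccccc3)=C2OCc2ccccc2)nn1`, keeps the core of compound 1. The difference is a group of 4 heavy atoms (3 carbon, 1 silicon; no ring) in place of a group of 11 heavy atoms (11 carbon; one six-membered aromatic ring of carbon only), on an aromatic carbon. The entering group is far smaller than the departing one, with no ring. For the measured compounds named here, no measured step of this kind is available, so the expectation rests on compound 1 alone. Compound 3 is expected to be weaker, with a step of a 3.0-fold higher number from compound 1 to compound 3 (0.47 log units; beyond the scatter), and an estimated value of 25000 nM, ranging from 6000 nM to 100000 nM.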

Compound 3, half-maximal inhibitory concentration: 22300 nM
Compound 3: middle estimate off by 1.1-fold (0.05 log units), on the high side; low and high end bracket the measured number.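

In this assay, replacing 4-pentylphenyl with the much smaller silicon-bearing group gives a 2.7-fold higher number from compound 1 to compound 3 (0.42 log units; beyond the scatter), a modest step and the first that can be read at this position. On the core of compound 1, this aromatic carbon of the five-membered aromatic ring with 3 nitrogen therefore keeps a measured value without the six-membered aromatic ring or the pentyl chain, although the number is higher. Nothing measured in this set accounts for the step.

The compounds shown leave open whether the difference follows the aromatic ring or the pentyl chain, as neither a plain phenyl group nor a hexyl chain stands at this position among them. Going by these compounds, how an amine or a carboxylic acid on this carbon would read also remains open.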